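The compounds below may be only part of what the source reports. "The series", "measured", "known", "first", "only" and "open" are said of these compounds alone.

Compound 3 `CN(C(=O)NC(=O)c1cccc(C(F)(F)F)c1)c1nc(C(F)(F)F)c(C(=O)N/N=C/c2ccccc2C(F)(F)F)s1` gives 12.1 ug/mL in a functional assay on A549 cells (Homo sapiens) for inhibition, read by MTT assay, with a stated time of 72 h (on this read-out higher numbers stand for weaker inhibition and lower numbers for stronger inhibition), and so carries the highest of the three measured numbers, though it lies within the scatter of compound 1 `CN(C(=O)NC(=O)c1ccc(Cl)cc1Cl)c1nc(C(F)(F)F)c(C(=O)N/N=C/c2ccc(C(F)(F)F)cc2)s1` at 9.4 ug/mL and of compound 2 `CN(C(=O)NC(=O)c1cccc(C(F)(F)F)c1)c1nc(C(F)(F)F)c(C(=O)N/N=C/c2ccc(C(F)(F)F)cc2)s1` at 6.2 ug/mL. Compound 4 `CN(C(=O)NC(=O)c1ccc(Cl)cc1Cl)c1nc(C(F)(F)F)c(C(=O)N/N=C/c2ccccc2C(F)(F)F)s1` differs from compound 3 by 2,4-dichlorophenyl in place of 3-(trifluoromethyl)phenyl on a carbonyl carbon. For the measured compounds named here, the same exchange, run in the opposite direction, is the only measured step that bears on it: a 1.5-fold lower number from compound 1 to compound 2 (0.18 log units; within the scatter). The other measured step, a 2.0-fold higher number from compound 2 to compound 3 (0.29 log units; within the scatter), concerns a different position and adds nothing here. The step is therefore expected to be a 1.2-fold higher number from compound 3 to compound 4 (0.09 log units; within the scatter), a change not beyond the scatter. Compound 4 is estimated at 15 ug/mL, with a range from 7 ug/mL to 30 ug/mL.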

Compound 4, half-maximal inhibitory concentration: 15.3 ug/mL
For compound 4 the middle estimate is 1.0-fold (0.01 log units) below the measured one; the range from low to high includes it.
By their numbers in this assay, from the lowest: compounds 2, 1, 3 and 4 (each within the scatter of the next, the first and the last beyond it).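

In this assay the exchange to 2,4-dichlorophenyl on a carbonyl carbon now reads a 1.3-fold higher number from compound 3 to compound 4 (0.10 log units; within the scatter) and agrees with the earlier step on the other core: the same change on two cores in this assay, a 1.5-fold lower number (0.18 log units; within the scatter) from compound 1 to compound 2 and a 1.3-fold lower number (0.10 log units; within the scatter) from compound 4 to compound 3, 1.2-fold (0.08 log units) apart, within the scatter of two such steps. The change to 2-(trifluoromethyl)phenyl on a carbon with a double bond to nitrogen likewise repeats as a 1.6-fold higher number from compound 1 to compound 4 (0.21 log units; within the scatter) and matches its earlier reading: the same change on two cores in this assay, a 2.0-fold higher number (0.29 log units; within the scatter) from compound 2 to compound 3 and a 1.6-fold higher number (0.21 log units; within the scatter) from compound 1 to compound 4, 1.2-fold (0.08 log units) apart, within the scatter of two such steps. Each change thus reads alike on both cores, and none of the four compounds goes against this.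

From the compounds shown here alone, whether a carboxylic acid or an amine on either aromatic ring would give a step beyond the scatter remains open.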